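The compounds below may be only part of what the source reports. "The series", "measured", "known", "first", "only" and "open" are said of these compounds alone.

In a functional assay on MCF7 cells (Homo sapiens) for antiproliferative activity, read by MTT assay, with a stated time of 48 h; a higher number here means a weaker inhibitor, a lower number a stronger inhibitor:

compound 1 `COc1cc(-c2cccc3nc(-c4cccc(Cl)c4)oc23)cc(OC)c1OC`: > 25000 nM
compound 2 `COc1cc(-c2cccc3nc(-c4ccc(Cl)cc4)oc23)cc(OC)c1OC`: > 25000 nM
compound 3 `COc1cc(-c2cccc3nc(-c4ccc(C)cc4)oc23)cc(OC)c1OC`: > 25000 nM

Each of these entries is a limit and not a number. Compound 1, compound 2 and compound 3 all share (the limit of > 25000 nM in this assay, at which 3 of the 3 values shown sit). Compound 3 therefore has no exact position, only its limit of > 25000 nM.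

Compound 4 `COc1cc(-c2cccc3nc(-c4cccc(C)c4)oc23)cc(OC)c1OC` has the same atoms as compound 3, joined differently: 3-methylphenyl in place of 4-methylphenyl, on an aromatic carbon of a five-membered aromatic ring with 1 nitrogen and 1 oxygen. 3-methylphenyl in place of 4-methylphenyl on an aromatic carbon

The nearest measured parallel is the same kind of shift made with chlorine, and it runs the opposite way: a step that the two limits leave unreadable from compound 1 to compound 2. The two other steps are a step that the two limits leave unreadable from compound 1 to compound 3 and a step that the two limits leave unreadable from compound 2 to compound 3. None of the three has a readable size, so they give no measured effect to carry over. Compound 1 carries 3-chlorophenyl, the group most like the entering 3-methylphenyl, and its result is the limit > 25000 nM.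

The expected result is no change beyond the scatter in this assay, and another limit is the most likely report. The estimated step is a step that the limit leaves unreadable from compound 3 to compound 4. For compound 4 the estimated value is 30000 nM, with an expected range from 15000 nM to 60000 nM.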

Compound 4, half-maximal inhibitory concentration: > 25000 nM
Compound 4: only a limit was reported; the forecaster's own chance of this, stated with the estimate: 85%; the middle value lies beyond the limit too.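

Compound 4 gives > 25000 nM, which is a limit and not a number. Going by these compounds alone, no step linking compound 4 with compound 1, compound 2 or compound 3 can be read, as all four share one limit: the limit of > 25000 nM in this assay, at which 4 of the 4 values shown sit. Whether 3-methylphenyl, 4-methylphenyl, 3-chlorophenyl and 4-chlorophenyl differ from one another in this assay stays open, as does the actual strength of any of these compounds.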